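A few compounds are considered here, and "the series" means these few. Any claim that something is new, unique, unknown or untested is made for them only; others in the source may bear on it.

Measured compounds:
compound 1 `CCc1ccc(NC(=O)C2CCN(C/C=C/c3ccccc3)CC2)cc1` gives 20000 nM in a functional assay on MCF7 cells (Homo sapiens) for inhibition, read by MTT assay, with a stated time of 72 h; a higher number here means a weaker inhibitor, a lower number a stronger inhibitor
compound 2 `CCCc1ccc(NC(=O)C2CCN(C/C=C/c3ccccc3)CC2)cc1` gives 9030 nM in this assay
compound 3 `O=C(Nc1cccc(C(F)(F)F)c1)C1CCN(C/C=C/c2ccccc2)CC1` gives 16100 nM in this assay

Compound 2 holds the lowest of the three numbers in this assay. Against compound 3 the gap is within the scatter, so the two cannot be ordered; against compound 1 the step is a 2.2-fold lower number from compound 1 to compound 2 (0.35 log units; beyond the scatter), which is beyond the scatter, though modest.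

Compound 4 `O=C(Nc1ccccn1)C1CCN(C/C=C/c2ccccc2)CC1` has not yet been measured in this assay. It differs from compound 2 in one place: pyridin-2-yl in place of 4-propylphenyl on an amide-type nitrogen. Going by the values given here, the only measured step, a 2.2-fold lower number from compound 1 to compound 2 (0.35 log units; beyond the scatter), concerns a single carbon added to the chain on the aryl group and does not bear directly on swapping the whole aryl group for a heteroaryl one. Compounds 1 and 3, with smaller or different aryl groups, both sit higher than compound 2, and nothing in the data points to a gain. Compound 4 is therefore expected to give a higher number than compound 2 in this assay, a step of about a 2.8-fold higher number from compound 2 to compound 4 (0.44 log units; beyond the scatter), with wide uncertainty. The estimate for compound 4 in this assay is 25000 nM, within a range from 8000 nM to 80000 nM.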

Compound 4, half-maximal inhibitory concentration: 67200 nM
Compound 4: the middle estimate sits 2.7-fold (0.43 log units) below what was measured; low and high end bracket the measured number.
By their numbers in this assay, from the lowest: compounds 2, 3 and 1 (each within the scatter of the next, the first and the last beyond it); then compound 4.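

Swapping the whole aryl group on the amide-type nitrogen moves the number in this assay further than trimming its chain did: pyridin-2-yl in place of 4-propylphenyl gives the larger step (a 7.4-fold higher number from compound 2 to compound 4 (0.87 log units; beyond the scatter)) and pyridin-2-yl in place of 4-ethylphenyl a smaller one (a 3.4-fold higher number from compound 1 to compound 4 (0.53 log units; beyond the scatter)). The earlier step showed only a modest shift with chain length, whereas these show that the identity of the aryl group matters at this position and that the loss appears from both 4-propylphenyl and 4-ethylphenyl. Nothing available explains this loss.

The compounds shown do not separate the effect of the ring nitrogen in pyridin-2-yl from that of losing the alkyl chain; an unsubstituted phenyl or a propyl-bearing pyridine would address this. On these data alone, whether a longer chain, such as butyl, would lower the number further also remains open.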